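Removing one methyl from the lowest-clearance phenol

The source may report more compounds than this note shows. Statements on the series, on what has been measured and on what is new or still open speak of the compounds shown alone.

Measured compounds:
- compound 1, `Cc1cc(C)c(O)c(-n2c(N)nc3ccccc32)c1`: 476 uL/min
- compound 2, `Cc1cc(O)c(-n2c(N)nc3ccccc32)cc1C`: 76 uL/min
- compound 3, `COc1ccc(-n2c(N)nc3ccccc32)c(O)c1`: 271 uL/min

Three analogues sharing one core have been tested in an ADME assay on microsomes from liver (Mus musculus) for metabolic stability, read by LC-MS, using NADPH, with a stated time of 60 min, tested at 1 uM; a higher number here means faster removal of the compound, a lower number slower removal. In this assay compound 1 gives 476 uL/min and compound 3 gives 271 uL/min. Compound 2 gives 76 uL/min and so stands lowest of the three numbers, with compound 3 nearest at a gap beyond the scatter and compound 1 furthest, also beyond the scatter.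

The next compound, compound 4, `Cc1ccc(-n2c(N)nc3ccccc32)c(O)c1`, has not yet been measured in this assay. It differs from compound 2 in one place: hydrogen in place of methyl on an aromatic carbon. Among the compounds with values here, no step between two measured compounds matches this change, so there is no direct precedent for its effect.

Given that compound 2 already sits at the low end, the step is expected to be modest, most likely a small rise that may not exceed the scatter, and the expected step is a 1.4-fold higher number from compound 2 to compound 4 (0.16 log units; within the scatter). Compound 4 is thus estimated at 110 uL/min in this assay, with a range from 50 uL/min to 250 uL/min.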

Compound 4, intrinsic clearance in a liver preparation (reported as CLH), per the amount of preparation that the assay uses in the Mus musculus assay: 97 uL/min
The estimate for compound 4 lay 1.1-fold (0.05 log units) above the measured number; low and high end bracket the measured number.
By their numbers in the Mus musculus assay, from the lowest: compounds 2 and 4 (each within the scatter of the next); then compounds 3 and 1 (each within the scatter of the next).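

In the Mus musculus assay, hydrogen in place of methyl on this aromatic carbon, para to a hydroxy group, gives a step that stays within the scatter (a 1.3-fold higher number from compound 2 to compound 4 (0.11 log units; within the scatter)), so methyl and hydrogen cannot be told apart here. On another aromatic carbon, methyl in place of methoxy gives a step beyond the scatter (a 2.8-fold lower number from compound 3 to compound 4 (0.45 log units; beyond the scatter)), the only readable step among these compounds. In a physicochemical assay for solubility, read by nephelometry, measured as kinetic solubility, with a stated time of 30 min, at pH 7.4 (a higher number here means a more soluble compound, a lower number a less soluble compound), compound 2 gives 12.5 ug/mL and compound 4 gives 25 ug/mL, and this step also stays within the scatter (a 2.0-fold higher number from compound 2 to compound 4 (0.30 log units; within the scatter)).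

Nothing measured here accounts for either step. As far as these compounds go, it remains open whether an amine, a carboxylic acid or a longer chain on the carbon para to the hydroxy group would match hydrogen and methyl in either assay.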